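This account rests on a few compounds, and the source may have more. Where it says the series, first, only, none or still open, it means among the compounds named here.

Measured in a functional assay on M21 cells (Homo sapiens) for antiproliferative activity, read by sulforhodamine B assay, with a stated time of 48 h; on this read-out lower numbers stand for stronger inhibition and higher numbers for weaker inhibition:
- compound 1 `O=C1NCCN1c1ccc(S(=O)(=O)Nc2ccccc2)cc1`: 200 nM
- compound 2 `O=C1NCCN1c1ccc(S(=O)(=O)Nc2cccc(Br)c2)cc1`: 59 nM
- compound 3 `O=C1NCCN1c1ccc(S(=O)(=O)Nc2ccc(Br)cc2)cc1`: 130 nM

Compound 3 stands at 130 nM, and of the other two compounds only compound 2 is separated from it by more than the scatter. Bromo in place of hydrogen gave a 1.5-fold lower number from compound 1 to compound 3 (0.19 log units; within the scatter) in one case and a 3.4-fold lower number from compound 1 to compound 2 (0.53 log units; beyond the scatter) in the other. The exchange between the two bromophenyl groups gave a 2.2-fold higher number from compound 2 to compound 3 (0.34 log units; beyond the scatter).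

The next compound is compound 4 `O=C1NCCN1c1ccc(S(=O)(=O)Nc2cccc(Cl)c2)cc1`, and the change is 3-chlorophenyl in place of 4-bromophenyl on a sulfonamide nitrogen. For the measured compounds named here, no chloro compound has yet been measured, so the exchange of halogen rests on no data. The closest guide is compound 2, which carries 3-bromophenyl and gives 59 nM. Read in reverse, the step of a 2.2-fold higher number from compound 2 to compound 3 (0.34 log units; beyond the scatter) suggests a lower number for compound 4 than for compound 3, though perhaps by a slightly smaller margin. The step expected in this assay is a 1.9-fold lower number from compound 3 to compound 4 (0.27 log units; within the scatter). For compound 4 the estimated value is 70 nM, with an expected range of 30 nM to 150 nM.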

Compound 4, half-maximal inhibitory concentration: 25 nM
Compound 4: middle estimate off by 2.8-fold (0.45 log units), on the high side, and the stated range ends above it.
By their numbers in this assay, from the lowest: compound 4; then compound 2; then compounds 3 and 1 (each within the scatter of the next).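

With the 3-bromophenyl and 3-chlorophenyl groups compared directly on the sulfonamide nitrogen, this assay shows that the identity of the halogen matters as well as its place: chloro in place of bromo gave a 2.4-fold lower number from compound 2 to compound 4 (0.37 log units; beyond the scatter) and placed compound 4 at the low end of the series. Measured against the unsubstituted phenyl group, chloro in place of hydrogen gave an 8.0-fold lower number from compound 1 to compound 4 (0.90 log units; beyond the scatter), a larger step than either bromo step, while the exchange of 4-bromophenyl for 3-chlorophenyl gave a 5.2-fold lower number from compound 3 to compound 4 (0.72 log units; beyond the scatter), though this last step alters the halogen and its place together and cannot be divided between them. Nothing available accounts for the difference between the chloro and bromo compounds.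

The compounds shown leave open how much of that last step belongs to the halogen and how much to its place, since the series holds no 4-chlorophenyl partner for compound 3. They also leave open whether fluoro, methyl, methoxy or trifluoromethyl on the phenyl group attached to the sulfonamide nitrogen would give a number lower still, or whether a second chloro on that ring would add to the step seen with the first.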